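This account rests on a few compounds, and the source may have more. Where it says the series, first, only, none or still open, it means among the compounds named here.

Measured in a functional assay on cells (T-cell line, Homo sapiens) for inhibition; a higher number here means a weaker inhibitor, a lower number a stronger inhibitor:
compound 1 `CN1CCC(COC(c2ccccc2)c2ccccc2)CC1`: > 20000 nM, a limit
compound 2 `CCN1CCC(COC(c2ccccc2)c2ccccc2)CC1`: > 20000 nM, a limit

Compound 2 stands only at a limit, > 20000 nM, so there is no number to start from. Compound 3 `CCCCCCCN1CCC(COC(c2ccccc2)c2ccccc2)CC1` carries pentyl in place of hydrogen on a saturated chain carbon, two bonds along the chain from an amine nitrogen in a ring. For the measured compounds named here, the one measured step, a step that the two limits leave unreadable from compound 1 to compound 2, has no readable size, and the limit of > 20000 nM in this assay, at which 2 of the 2 values shown sit, is all the series shows so far. The data therefore fix no size in this assay. A shift toward stronger inhibition is expected, though another limit remains quite possible. The estimated shift is an at least 4.0-fold lower number from compound 2 to compound 3 (0.60 log units; beyond the scatter). Compound 3 is estimated at 5000 nM, with an expected range of 800 nM to 20000 nM.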

Compound 3, half-maximal inhibitory concentration: 500 nM
The estimate for compound 3 lay 10-fold (1.00 log units) above the measured number; the whole stated range lies above it.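

In this assay, the place two bonds along the chain from an amine nitrogen in a ring now gives a first readable step: pentyl in place of hydrogen gives an at least 40-fold lower number from compound 2 to compound 3 (1.60 log units; beyond the scatter). The same chain counted from compound 1, as hexyl in place of hydrogen on a saturated chain carbon bound to that nitrogen, gives an at least 40-fold lower number from compound 1 to compound 3 (1.60 log units; beyond the scatter). The step between the two shorter chains still cannot be read.

Open, as far as these compounds go, is how the value runs with chain length between ethyl and heptyl, and whether a longer chain goes further. Also open, from the compounds shown here alone, is whether a chain ending in a carboxylic acid or an amine would hold the value of compound 3.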